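The source may hold more compounds than are shown below. What is called first, only, known or untested is meant among the compounds shown, and "the series" means these compounds.

Working notes on the series.

Compound 1 `COc1ccc(OC)c(/C=N/NC(=O)Nc2ccc(Oc3ccnc(-c4nncn4CCN(C)C)c3)c(F)c2)c1` and compound 2 `CN(C)CCn1cnnc1-c1cc(Oc2ccc(NC(=O)N/N=C/c3c(O)ccc4ccccc34)cc2F)ccn1` share the same core and differ only in the aryl group on the carbon with a double bond to nitrogen. In a functional assay on NCI-H460 cells (Homo sapiens) for cytotoxicity, read by MTT assay, with a stated time of 72 h (a lower number here means a stronger inhibitor, a higher number a weaker inhibitor), compound 1 gives 2930 nM, and compound 2 gives 890 nM; the step of a 3.3-fold lower number from compound 1 to compound 2 (0.52 log units; beyond the scatter) is the only one measured so far, so compound 2 holds the lowest number of the two.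

Compound 3 `CN(C)CCn1cnnc1-c1cc(Oc2ccc(NC(=O)N/N=C/c3ccc(F)cc3Cl)cc2F)ccn1` is not yet measured. It differs from compound 2 by 2-chloro-4-fluorophenyl in place of 2-hydroxynaphthalen-1-yl on a carbon with a double bond to nitrogen. Going by the values given here, no measured step concerns this exchange; the one known step moves from a two-ring to a one-ring aryl group in the opposite sense, so it gives only a weak hint. A step in the direction of compound 1, smaller than that one, is expected. Compound 3 is estimated at 2000 nM, range 700 nM to 6000 nM, meaning an expected step of a 2.2-fold higher number from compound 2 to compound 3 (0.35 log units; beyond the scatter).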

Compound 3, half-maximal inhibitory concentration: 720 nM
For compound 3 the middle estimate is 2.8-fold (0.44 log units) above the measured one, within the range that was stated.
By their numbers in this assay, from the lowest: compounds 3 and 2 (each within the scatter of the next); then compound 1.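

In this assay, the result a 1.2-fold lower number from compound 2 to compound 3 (0.09 log units; within the scatter) shows that, on the carbon with a double bond to nitrogen, a group with one aromatic ring and no hydrogen-bond donor or acceptor can stand level with the two-ring 2-hydroxynaphthalen-1-yl. The position still separates the two one-ring groups: 2-chloro-4-fluorophenyl in place of 2,5-dimethoxyphenyl gives a 4.1-fold lower number from compound 1 to compound 3 (0.61 log units; beyond the scatter). So the gap between compound 1 and compound 2 cannot be read simply as one ring against two. No data on hand explain either step.

Whether the chlorine, the fluorine or their combination accounts for the gap from compound 1 remains open, as does the separate contribution of each methoxy group. Also open, from the compounds shown here alone, is where an unsubstituted phenyl, or a phenyl carrying a carboxylic acid or a primary amine, would fall at this position.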